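Fluoro in Place of Chloro on the Shared Core

The source may report more compounds than this note shows. Statements on the series, on what has been measured and on what is new or still open speak of the compounds shown alone.

Three compounds built on the shared core were measured in a functional assay on NCI/ADR-RES cells (Homo sapiens) for inhibition, read by sulforhodamine B assay, with a stated time of 48 h; on this read-out higher numbers stand for weaker inhibition of growth and lower numbers for stronger inhibition of growth. Compound 1 `N=C(N)c1ccc(-c2ccc(-c3cc(Cl)cc(Cl)c3)s2)s1` gives 2060 nM. Compound 2 `N=C(N)c1ccc(-c2ccc(-c3ccc(Cl)cc3)o2)o1` gives 1800 nM. Compound 3 `N=C(N)c1ccc(-c2ccc(-c3cncc4ccccc34)s2)s1` gives 1680 nM. Among these three numbers compound 2 stands second highest; its nearest neighbour is compound 3 and its furthest is compound 1, yet both gaps lie within the scatter of repeated measurements, so no order among the three can be read from them.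

Compound 4 `N=C(N)c1ccc(-c2ccc(-c3ccc(F)cc3)o2)o1` has not yet been measured in this assay. It differs from compound 2 in one place: fluoro in place of chloro on an aromatic carbon. Among the measured compounds shown here, no step between two measured compounds resembles this change, so the data give nothing from which to size it directly. The change is small, and the three measured compounds, though unlike at this end of the core, all fall close together in this assay. Compound 4 is therefore expected to give about 2400 nM, between 1000 nM and 6000 nM. The expected step of a 1.3-fold higher number from compound 2 to compound 4 (0.12 log units; within the scatter) is estimated to stay within the scatter.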

Compound 4, concentration for 50% growth inhibition: 1680 nM
Estimate against measurement, compound 4: 1.4-fold (0.15 log units) above, and the stated range covers the measured number.
By their numbers in this assay, from the lowest: compounds 3, 4, 2 and 1 (each within the scatter of the next).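

In this assay, the step of a 1.1-fold lower number from compound 2 to compound 4 (0.03 log units; within the scatter) lies within the scatter, so fluoro in place of chloro at this position, para to a large group on a six-membered aromatic ring of carbon only, produces no change that can be read. Among the compounds shown here, the earlier compounds held no pair differing in one place, so this is the first direct reading of any change on the shared core, and it covers these two halogens only. Nothing measured here bears on why the two compounds read alike.

From the compounds shown here alone, it remains open whether an amine, a carboxylic acid or a methoxy group at this position would give a step beyond the scatter. Also open, going by these compounds, is whether fluoro in place of chloro would read the same on the core of compound 1.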